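Replacing 2-hydroxyphenyl with 3-methylphenyl on the carbonyl carbon

The source may hold more compounds than are shown below. What is called first, only, known or untested is meant among the compounds shown, and "the series" means these compounds.

Compound 1 `O=C(Nc1cc(-c2ccccc2)nn1-c1ccccc1)c1ccccc1` gives 40 nM in an assay on CHO cells with metabotropic glutamate receptor 5 (Homo sapiens) as the target; a lower number here means that less compound is needed, a higher number that more compound is needed for the effect. Compound 2 `O=C(Nc1cc(-c2ccccc2)nn1-c1ccccc1)c1ccsc1` gives 1800 nM in this assay, a step of a 45-fold higher number from compound 1 to compound 2 (1.65 log units; beyond the scatter). For compound 3 `O=C(Nc1cc(-c2ccccc2)nn1-c1ccccc1)c1ccccc1O` only a limit is reported in this assay, namely > 10000 nM. Compound 3 thus stands at the weak end of the three measured compounds, sitting at the limit of > 10000 nM in this assay, at which 1 of the 3 values shown sits, with an at least 250-fold higher number from compound 1 to compound 3 (2.39 log units; beyond the scatter) and an at least 5.5-fold higher number from compound 2 to compound 3 (0.74 log units; beyond the scatter). Compound 4 `Cc1cccc(C(=O)Nc2cc(-c3ccccc3)nn2-c2ccccc2)c1` differs from compound 3 by 3-methylphenyl in place of 2-hydroxyphenyl on a carbonyl carbon. Since compound 1 carries plain phenyl on this carbonyl carbon and gives 40 nM, while hydroxy on an aromatic carbon cost an at least 250-fold higher number from compound 1 to compound 3 (2.39 log units; beyond the scatter), compound 4 is expected to return close to compound 1. Compound 4 is therefore estimated at 60 nM, between 15 nM and 300 nM, which would be a step of an at least 160-fold lower number from compound 3 to compound 4 (2.22 log units; beyond the scatter).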

Compound 4, half-maximal effective concentration: 90 nM
Estimate against measurement, compound 4: 1.5-fold (0.18 log units) below; the range from low to high includes it.
By their numbers in this assay, from the lowest: compound 1; then compound 4; then compound 2. At a limit, above all of these: compound 3.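

Compound 3 is reported only as a limit: the limit of > 10000 nM in this assay, at which 1 of the 4 values shown sits. Against that limit, 3-methylphenyl on the carbonyl carbon gives an at least 110-fold lower number from compound 3 to compound 4 (2.04 log units; beyond the scatter), and it also outperforms thiophen-3-yl, with a 20-fold lower number from compound 2 to compound 4 (1.30 log units; beyond the scatter), so a substituted phenyl can keep most of the potency at this position. The added methyl still has a modest cost against plain phenyl: a 2.3-fold higher number from compound 1 to compound 4 (0.35 log units; beyond the scatter). The compounds shown leave open whether 2-methylphenyl would behave like 3-methylphenyl or like 2-hydroxyphenyl, and whether 3-hydroxyphenyl would share the loss seen with 2-hydroxyphenyl. As far as these compounds go, the outcome with an amine or a carboxylic acid on this phenyl also remains open.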